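The source may hold more compounds than are shown below. What is called first, only, known or untested is meant among the compounds shown, and "the series" means these compounds.

Compound 2 `CC1CCN(C2CCN(S(=O)(=O)c3cccc(Br)c3)CC2)CC1` gives 0.217 h in an ADME assay on S9 fraction from liver (Mus musculus, strain ICR/CD-1) for metabolic stability, read by LC-MS, using NADPH, with a stated time of 5 min, tested at 2 uM (a higher number here means that the compound lasts longer, a lower number that the compound disappears faster), which places it lowest of the two numbers measured, though only inside the usual scatter, as compound 1 `CC1CCN(C2CCN(S(=O)(=O)c3cccc(-c4ccccc4F)c3)CC2)CC1` gives 0.283 h. Compound 3 `Cc1ccc(-c2cccc(S(=O)(=O)N3CCC(N4CCC(C)CC4)CC3)c2)cc1` has not yet been measured; it differs from compound 2 by 4-methylphenyl in place of bromo on an aromatic carbon. Among the measured compounds shown here, the only measured step bears on this change in reverse: a 1.3-fold lower number from compound 1 to compound 2 (0.12 log units; within the scatter). Since that step stayed within the scatter, the change from compound 2 to compound 3 is expected to stay within the scatter as well, with no clear direction. Compound 3 is therefore estimated at 0.25 h, between 0.12 h and 0.5 h, meaning a 1.2-fold higher number from compound 2 to compound 3 (0.06 log units; within the scatter).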

Compound 3, half-life: 1.92 h
The estimate for compound 3 lay 7.7-fold (0.89 log units) below the measured number, and the stated range ends below it.
By their numbers in this assay, from the lowest: compounds 2 and 1 (each within the scatter of the next); then compound 3.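

At this place on the aromatic ring, the choice of group can matter a great deal in this assay: 4-methylphenyl in place of bromo gives an 8.8-fold higher number from compound 2 to compound 3 (0.95 log units; beyond the scatter), and 4-methylphenyl in place of 2-fluorophenyl gives a 6.8-fold higher number from compound 1 to compound 3 (0.83 log units; beyond the scatter). A second aromatic ring alone therefore does not settle the number, as compound 1 also carries one yet lies within the scatter of compound 2. Nothing shown here explains this difference between the two added rings. On these data alone, it remains open whether the methyl on the added ring is what matters, and how an unsubstituted phenyl, an amine or a carboxylic acid at this place would compare.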